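A few compounds are considered here, and "the series" means these few. Any claim that something is new, unique, unknown or untested is made for them only; others in the source may bear on it.

Compound 2 `CN(Cc1ccsc1)C1CCN(CCCc2c[nH]c3ccc(-n4cnnc4)cc23)CC1` and compound 1 `CN(Cc1cccs1)C1CCN(CCCc2c[nH]c3ccc(-n4cnnc4)cc23)CC1` share one core and differ only in the group attached to the amine nitrogen. In an assay on CHO cells for agonist activity at 5-hydroxytryptamine receptor 1D (Homo sapiens), read by GTPgammaS binding (a higher number here means that more compound is needed for the effect, a lower number that less compound is needed), compound 2 gives 4.2 nM, and compound 1 gives 3.5 nM; the step of a 1.2-fold higher number from compound 1 to compound 2 (0.08 log units; within the scatter) lies within the scatter, so the two stand level. Compound 3 `c1ccc2c(c1)CCC2NCC1CCN(CCCc2c[nH]c3ccc(-n4cnnc4)cc23)CC1` carries a larger change: ((2,3-dihydro-1H-inden-1-yl)amino)methyl in place of methyl((thiophen-3-yl)methyl)amino on a saturated ring carbon. For the measured compounds named here, no measured step resembles this change, and the single step seen is within the scatter, so it gives no direction. Compound 3 is therefore estimated at 10 nM, with a range from 2 nM to 60 nM. The expected step is a 2.4-fold higher number from compound 2 to compound 3 (0.38 log units; beyond the scatter), and that expectation is loose.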

Compound 3, half-maximal effective concentration: 1.3 nM
Compound 3: the middle estimate sits 7.7-fold (0.89 log units) above what was measured, outside the stated range (below it).
By their numbers in this assay, from the lowest: compound 3; then compounds 1 and 2 (each within the scatter of the next).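

In this assay, the saturated ring carbon of the shared core tolerates far more than the exchange of one thiophene for another: ((2,3-dihydro-1H-inden-1-yl)amino)methyl gives a 3.2-fold lower number from compound 2 to compound 3 (0.51 log units; beyond the scatter) and a 2.7-fold lower number from compound 1 to compound 3 (0.43 log units; beyond the scatter). Both steps lie beyond the scatter, so changing the whole group here does shift the number, towards less compound needed. No available evidence explains this shift. The swap alters the ring system, the methyl on the amine nitrogen and the link to the ring carbon all at once, and the compounds shown cannot separate these changes. Going by these compounds, whether a simpler (benzylamino)methyl group would match compound 3 remains open.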